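Methyl on the shared ring: notes on a small series

A few compounds are considered here, and "the series" means these few. Any claim that something is new, unique, unknown or untested is made for them only; others in the source may bear on it.

Measured compounds:
compound 1 `CC(Cn1ncccc1=O)C(=N)S`: 40.3%
compound 2 `N=C(S)CCn1ncccc1=S`: 50%
compound 3 `Cc1ccc(=S)n(CCC(=N)S)n1`: 48.5%

In a functional assay on the whole organism (stomach) for inhibition, with Rattus norvegicus as the target, at a dose of 100 mg/kg by the intraduodenal route (on this read-out lower numbers stand for less inhibition and higher numbers for more inhibition at the one dose given (going by the name of the read-out)), compound 1 gives 40.3% and compound 2 gives 50%; the difference between their two cores is not broken down here. Relative to compound 2, compound 3 carries methyl in place of hydrogen on an aromatic carbon and gives 48.5%; the step is a number 1.5 percentage points lower from compound 2 to compound 3 (within the scatter). Compound 4 `Cc1ccc(=O)n(CC(C)C(=N)S)n1` is not yet measured and carries, relative to compound 1, (methyl in place of hydrogen on an aromatic carbon). This is the same kind of change as from compound 2 to compound 3, though not the same: in compound 1 the place is meta to a group of 6 heavy atoms, in compound 2 meta to a group of 5 heavy atoms. Resting on the step of a number 1.5 percentage points lower from compound 2 to compound 3 (within the scatter), the expected step from compound 1 to compound 4 is a number 0.3 percentage points lower from compound 1 to compound 4 (within the scatter). Compound 4 is therefore estimated at 40%, expected between 28% and 53%.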

Compound 4, a percentage reported as inhibition, in the whole organism at one dose (the size of the read-out at that dose, not a potency): 30.2%
Estimate against measurement, compound 4: 9.8 percentage points above, within the range that was stated.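

On the core of compound 1, methyl in place of hydrogen on an aromatic carbon gives, in this assay, a number 10.1 percentage points lower from compound 1 to compound 4 (beyond the scatter). Set beside the same change on the other core, the two steps cannot be told apart: the same change on two cores in this assay, a number 1.5 percentage points lower (within the scatter) from compound 2 to compound 3 and a number 10.1 percentage points lower (beyond the scatter) from compound 1 to compound 4, 8.6 percentage points apart, within the scatter of two such steps This allows the change to be carried between these two cores without a shown difference, but it does not prove that the cores respond alike, and one pair per core shows no general rule for the series.

As far as these compounds go, whether an ethyl group, a methoxy group or an amine in place of methyl would follow the same course in this assay stays open. The compounds shown also leave open how a longer chain at that place would read out on either core.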